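The compounds below may be only part of what the source reports. "The series", "measured", "known", "first", "only" and "open" are said of these compounds alone.

Compound 1 `O=C(Nc1ccc2c(c1)B(O)OC2)c1ccccc1C(F)(F)F`: 2100 nM
Compound 2 `COc1ccccc1C(=O)Nc1ccc2c(c1)B(O)OC2`: > 100000 nM, a limit
Compound 3 `O=C(Nc1ccc2c(c1)B(O)OC2)c1ccccc1-c1ccccc1`: > 100000 nM, a limit

Within the data shown here, in a functional assay on PBMC cells (Homo sapiens) for inhibition, read by HTRF, with stated times of 15 min and 24 h (a higher number here means a weaker inhibitor, a lower number a stronger inhibitor), compound 1 gives 2100 nM, the only real number of the three, and it is the strongest of them. Compound 4 `O=C(Nc1ccc2c(c1)B(O)OC2)c1c(F)cccc1C(F)(F)F` keeps the trifluoromethyl group of compound 1 and changes it thus: fluoro in place of hydrogen on an aromatic carbon. Two measured steps replace that trifluoromethyl group: an at least 47-fold higher number from compound 1 to compound 2 (1.67 log units; beyond the scatter) and an at least 47-fold higher number from compound 1 to compound 3 (1.67 log units; beyond the scatter). Both are large and beyond the scatter, but neither adds fluoro in place of hydrogen, so they bear on this change only loosely. No step beyond the scatter is therefore expected, and the estimated step is a 1.4-fold lower number from compound 1 to compound 4 (0.15 log units; within the scatter). For compound 4 the expected value is 1500 nM, with an estimated range of 400 nM to 6000 nM.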

Compound 4, half-maximal inhibitory concentration: 180 nM
Beside the measured number, compound 4's estimate is 8.3-fold (0.92 log units) above it; measured number below the stated range.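

In this assay fluoro in place of hydrogen, with the trifluoromethyl group kept, gives a 12-fold lower number from compound 1 to compound 4 (1.07 log units; beyond the scatter) on an aromatic carbon ortho to a large group. The earlier steps only replaced trifluoromethyl and each raised the number, whereas this is the first step shown that lowers it, and it does so at a second place on the aromatic ring. Nothing measured here gives a cause for this step. From the compounds shown here alone, whether chloro, methyl or an amine at this position would give a step of like size stays open. Also open, going by these compounds, is whether fluoro would bring compound 2 or compound 3, each recorded only as a limit, to a readable number.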